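Sulfoxide to sulfide and the piperidine swap

The source may hold more compounds than are shown below. What is called first, only, known or untested is meant among the compounds shown, and "the series" means these compounds.

Compound 1 `CN(C)C1CCN(c2ccc(Nc3ncc4nc([S+]([O-])c5ccccc5)n(C5CCOCC5)c4n3)cc2)CC1` is the sulfoxide parent of this set; in a functional assay on HCC827 cells (Homo sapiens) for antiproliferative activity, read by MTT assay, with a stated time of 72 h (on this read-out lower numbers stand for stronger inhibition and higher numbers for weaker inhibition), compound 1 gives 1290 nM. Compound 2 `CN1CCC(Oc2ccc(Nc3ncc4nc([S+]([O-])c5ccccc5)n(C5CCOCC5)c4n3)cc2)CC1` carries the ether-linked piperidine on the aniline ring, and in this assay compound 2 gives 853 nM. The step of a 1.5-fold lower number from compound 1 to compound 2 (0.18 log units; within the scatter) is small; the change made is (1-methylpiperidin-4-yl)oxy in place of 4-(dimethylamino)piperidin-1-yl on an aromatic carbon. Compound 3 `CN(C)C1CCN(c2ccc(Nc3ncc4nc(Sc5ccccc5)n(C5CCOCC5)c4n3)cc2)CC1` keeps the amine-linked piperidine of compound 1 but has the sulfide core; in this assay compound 3 gives 29.4 nM. The step of a 44-fold lower number from compound 1 to compound 3 (1.64 log units; beyond the scatter) is the large move of the set, and the two cores differ as a group of 7 heavy atoms (6 carbon, 1 sulfur; one six-membered aromatic ring of carbon only) in place of a group of 8 heavy atoms (6 carbon, 1 oxygen, 1 sulfur; one six-membered aromatic ring of carbon only), on an aromatic carbon.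

Within the data shown here, compound 4 `CN1CCC(Oc2ccc(Nc3ncc4nc(Sc5ccccc5)n(C5CCOCC5)c4n3)cc2)CC1` is the sulfide core of compound 3 carrying the piperidine ether of compound 2; the change is (1-methylpiperidin-4-yl)oxy in place of 4-(dimethylamino)piperidin-1-yl on an aromatic carbon, the same change as the one from compound 1 to compound 2, at the same place.

Because a 1.5-fold lower number from compound 1 to compound 2 (0.18 log units; within the scatter) stayed within the scatter on the sulfoxide core, a step of similar size, a 1.3-fold lower number from compound 3 to compound 4 (0.13 log units; within the scatter), is expected on the sulfide core. Compound 4 is therefore estimated at 22 nM in this assay, with a likely range from 9 nM to 55 nM; compound 3 alone is the anchor, so the range is kept wide.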

Compound 4, half-maximal inhibitory concentration: 140 nM
Estimate against measurement, compound 4: 6.4-fold (0.80 log units) below, and the stated range ends below it.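

In this assay the change to (1-methylpiperidin-4-yl)oxy does not carry over unchanged from the core of compound 1 to the core of compound 3, where it gives a 4.8-fold higher number from compound 3 to compound 4 (0.68 log units; beyond the scatter), and the two steps disagree: the same change on two cores in this assay, a 1.5-fold lower number (0.18 log units; within the scatter) from compound 1 to compound 2 and a 4.8-fold higher number (0.68 log units; beyond the scatter) from compound 3 to compound 4, 7.2-fold (0.86 log units) apart, beyond the scatter of two such steps

Read along the other edge, the sulfoxide-to-sulfide change keeps its direction but not its size, giving a 6.1-fold lower number from compound 2 to compound 4 (0.78 log units; beyond the scatter) on the ether-linked piperidine, and the two steps again disagree: the same change on two cores in this assay, a 44-fold lower number (1.64 log units; beyond the scatter) from compound 1 to compound 3 and a 6.1-fold lower number (0.78 log units; beyond the scatter) from compound 2 to compound 4, 7.2-fold (0.86 log units) apart, beyond the scatter of two such steps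

These four compounds show that the two changes do not add up in this one cell line, but they form a single pair of pairs, so they do not show why, nor whether the same holds for other side chains.

Still open, going by these compounds, is where a sulfone would fall relative to the sulfide and sulfoxide cores. Also open, on these data alone, is whether a 4-methylpiperazin-1-yl group in place of either piperidine group would respond to the core as the amine-linked or the ether-linked piperidine does.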